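A Linker Swap on a Cell-Based Inhibition Read-Out

A few compounds are considered here, and "the series" means these few. Any claim that something is new, unique, unknown or untested is made for them only; others in the source may bear on it.

Of the compounds shown here, three that share one core have been measured in a functional assay on NCI-H1299 cells (Homo sapiens) for inhibition, read by CCK-8 assay, with a stated time of 72 h, tested at 1 uM; on this read-out lower numbers stand for a weaker effect and higher numbers for a stronger effect at the one concentration tested. Compound 1 `CN(C)C(=O)c1cc2cnc(Nc3ccc(S(=O)(=O)NCCCCN=C=S)cc3)nc2n1C1CCCC1` gives 29.9%. Compound 3 `CN(C)C(=O)c1cc2cnc(Nc3ccc(C(=O)NCCCCCN=C=S)cc3O)nc2n1C1CCCC1` gives 22.6%, a number within the scatter of compound 1, so the two cannot be put in order. Compound 2 `CN(C)C(=O)c1cc2cnc(Nc3ccc(C(=O)NCCCCCCCN=C=S)cc3F)nc2n1C1CCCC1` gives -9.23%, which lies below compound 1 by more than the scatter. Compound 1 therefore carries the highest of the three numbers, while compound 3 sits in the same band with it.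

Compound 4 `CN(C)C(=O)c1cc2cnc(Nc3ccc(NC(=O)CCCCCN=C=S)cc3)nc2n1C1CCCC1` has not yet been measured. It differs from compound 1 at one place: a group of 11 heavy atoms (7 carbon, 2 nitrogen, 1 oxygen, 1 sulfur; no ring) in place of a group of 11 heavy atoms (5 carbon, 2 nitrogen, 2 oxygen, 2 sulfur; no ring), on an aromatic carbon. The group that leaves and the group that enters are of the same size in heavy atoms, and neither contains a ring, but they are built of different atoms and carry different numbers of double bonds outside aromatic rings.

Going by the values given here, no pair of measured compounds differs by this change alone; compounds 2 and 3 each differ from compound 1 in several places at once, so their numbers cannot be tied to any single change. On that basis the account expects the step of a number 9.9 percentage points lower from compound 1 to compound 4 (within the scatter) to be a small lowering, close to the edge of the scatter and possibly not beyond it. Compound 4 is estimated to give 20%, with a range from -5% to 40%.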

Compound 4, a percentage reported as inhibition, at one concentration (the size of the read-out at that concentration, not a potency): 34.3%
The estimate for compound 4 lay 14.3 percentage points below the measured number, and the stated range covers the measured number.
By their numbers in this assay, from the lowest: compound 2; then compounds 3, 1 and 4 (each within the scatter of the next, the first and the last beyond it).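

In this assay, going by these compounds alone, the exchange on an aromatic carbon, para to a large group, gives a number 4.4 percentage points higher from compound 1 to compound 4 (within the scatter), the first step that can be tied to a single place. It shows that, on the shared core, the group of 11 heavy atoms with 5 carbon, 2 nitrogen, 2 oxygen and 2 sulfur atoms can give way to the group of the same size with 7 carbon, 2 nitrogen, 1 oxygen and 1 sulfur atom without the number leaving the scatter, even though the count of double bonds outside aromatic rings and the count of hydrogen-bond acceptors both differ between the two groups. Nothing at hand bears on why the two numbers stay within the scatter of each other.

The compounds shown leave open whether a chain ending in an amine or a carboxylic acid at this place would stay in the same band as compound 1 and compound 4. They also leave open how a longer chain within the entering group would read on the same core, since this one step covers a single exchange tested at one concentration.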